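Chloro in Place of Nitro on the Aryl Ring

The source may report more compounds than this note shows. Statements on the series, on what has been measured and on what is new or still open speak of the compounds shown alone.

Measured so far in a functional assay on HCT-116 cells (Homo sapiens) for cytotoxicity, read by MTT assay, with a stated time of 72 h; on this read-out higher numbers stand for weaker inhibition and lower numbers for stronger inhibition:
compound 1, `COc1cccc(/C=N/c2c(C)n(C)n(-c3ccccc3)c2=O)c1`, gives 933000000 nM
compound 2, `Cc1c(/N=C/c2cccc([N+](=O)[O-])c2)c(=O)n(-c2ccccc2)n1C`, gives 363000000 nM

Compound 2 holds the lowest of the two numbers in this assay; the nearest is compound 1, and the step of a 2.6-fold lower number from compound 1 to compound 2 (0.41 log units; beyond the scatter) lies beyond the scatter. Compound 3, `Cc1c(/N=C/c2cccc(Cl)c2)c(=O)n(-c2ccccc2)n1C`, is not yet measured. It differs from compound 2 in one place: chloro in place of nitro on an aromatic carbon. Within the data shown here, the only measured step that bears on this position is the one from methoxy to nitro, a 2.6-fold lower number from compound 1 to compound 2 (0.41 log units; beyond the scatter), which was modest. Among the measured compounds shown here, no step from nitro to chloro has been measured, so the direction of the change in this assay is open, and a step of no more than modest size is expected, a 1.4-fold higher number from compound 2 to compound 3 (0.14 log units; within the scatter). On that basis compound 3 is estimated to give 500000000 nM in this assay, with a range from 150000000 nM to 1500000000 nM.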

Compound 3, half-maximal inhibitory concentration: 912000000 nM
Estimate against measurement, compound 3: 1.8-fold (0.26 log units) below; the range from low to high includes it.
By their numbers in this assay, from the lowest: compound 2; then compounds 3 and 1 (each within the scatter of the next).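

In this assay, chloro in place of nitro gives a 2.5-fold higher number from compound 2 to compound 3 (0.40 log units; beyond the scatter), a modest step of about the same size as a 2.6-fold lower number from compound 1 to compound 2 (0.41 log units; beyond the scatter). Chloro and methoxy at this place on the aromatic ring cannot be told apart, with a 1.0-fold lower number from compound 1 to compound 3 (0.01 log units; within the scatter). Among these three groups, then, nitro alone stands apart, since compound 2 lies beyond the scatter of both other compounds, while the two non-nitro groups give values within the scatter of each other.

No evidence is available on why nitro differs from the other two groups. As far as these compounds go, it also remains open whether an amine or a carboxylic acid at this place would side with nitro or with chloro and methoxy, and whether the nitro result would hold at another place on the ring.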